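This account rests on a few compounds, and the source may have more. Where it says the series, first, only, none or still open, it means among the compounds named here.

Working notes on the series. Compound 2 `CCCCCCCCOc1ccc2c(Cl)ccnc2c1` is measured in a functional assay on RKO cells (Homo sapiens) for cytotoxicity, read by MTT assay, with a stated time of 48 h (a lower number here means a stronger inhibitor, a higher number a weaker inhibitor), and gives 3640 nM. Compound 1 `CC(C)COc1ccc2c(Cl)ccnc2c1` in this assay gives 2680 nM, and compound 3 `CN(C)CCNc1ccnc2cc(OCc3ccccc3)ccc12` gives 2350 nM; both sit within the scatter of compound 2, so none of the three can be set apart from the others. The step under consideration leads to compound 4 `Clc1ccnc2cc(OCCCc3ccccc3)ccc12`, in which the change is phenyl in place of pentyl on a saturated chain carbon, three bonds along the chain from an oxygen on an aromatic ring. Going by the values given here, no pair of measured compounds separates this kind of change, and the three measured numbers themselves give no room for a trend. The expectation is therefore a step from compound 2 to compound 4 of a 1.2-fold lower number from compound 2 to compound 4 (0.08 log units; within the scatter), none beyond the scatter. Compound 4 is estimated at 3000 nM in this assay, with a range from 1200 nM to 7500 nM.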

Compound 4, half-maximal inhibitory concentration: 1420 nM
Estimate against measurement, compound 4: 2.1-fold (0.32 log units) above; the range from low to high includes it.
By their numbers in this assay, from the lowest: compounds 4, 3, 1 and 2 (each within the scatter of the next, the first and the last beyond it).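

Phenyl in place of pentyl on a saturated chain carbon, three bonds along the chain from an oxygen on an aromatic ring, gives in this assay a 2.6-fold lower number from compound 2 to compound 4 (0.41 log units; beyond the scatter). The group on this carbon can therefore shift the number, which compound 1, compound 2 and compound 3 could not show, as their numbers stay within the scatter of one another. As far as these compounds go, whether a cyclohexyl group, a pyridine ring or an amine on the same carbon would give a step of similar size remains open. Nothing available accounts for this step.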